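Amino to hydrogen on compound 1

A few compounds are considered here, and "the series" means these few. Any claim that something is new, unique, unknown or untested is made for them only; others in the source may bear on it.

Measured in a functional assay on CCRF-CEM cells (Homo sapiens) for inhibition (on this read-out higher numbers stand for weaker inhibition and lower numbers for stronger inhibition), both entries limits:
compound 1 `Nc1nc(O)c2ncn([C@@H]3O[C@@H](CO)C=C3F)c2n1`: > 100000 nM
compound 2 `Nc1ccn([C@@H]2O[C@@H](CO)C=C2F)c(=O)n1`: > 100000 nM

Compound 1 stands only at a limit, with no number behind it. Compound 2 stands at the same limit: the limit of > 100000 nM in this assay, at which 2 of the 2 values shown sit.

Compound 3 `OC[C@H]1C=C(F)[C@H](n2cnc3c(O)ncnc32)O1` is not yet measured. It differs from compound 1 by hydrogen in place of amino on an aromatic carbon, with hydrogen in place of amino on an aromatic carbon. For the measured compounds named here, no measured step exists to size this change.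

The expectation in this assay is no step beyond the scatter, in neither direction, and it rests on compound 1 at > 100000 nM. The estimated change is a number no higher from compound 1 to compound 3 (the limit leaves the size open). Compound 3 is expected at 100000 nM, within an estimated range of 40000 nM to 200000 nM.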

Compound 3, half-maximal inhibitory concentration: > 100000 nM
Compound 3 ended at the assay's limit (the forecaster's own chance of this, stated with the estimate: 90%); the middle value sits exactly at the limit.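

No step can be read from compound 1 to compound 3 in this assay, as both values are limits: the limit of > 100000 nM in this assay, at which 3 of the 3 values shown sit.

The compounds shown leave open whether hydrogen in place of amino on an aromatic carbon changes inhibition at all: none of them carries a number.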